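This account rests on a few compounds, and the source may have more. Where it says the series, first, only, none or still open, it means among the compounds named here.

Three esters of the shared core carry numbers in an in vitro functional assay on HEK ts201 cells for antagonist activity at Neuronal acetylcholine receptor; alpha3/beta4 (Homo sapiens), read by fluorescence and calcium flux; on this read-out lower numbers stand for stronger inhibition and higher numbers for weaker inhibition. Compound 3 `CC1CC(=O)N(c2ccccc2C(=O)OCC2CCCN(CCCCCc3ccccc3)C2)C1=O` gives 4170 nM, the higher of the two single numbers, while compound 1 `[N-]=[N+]=NCCCN1CCCC(COC(=O)c2ccccc2-c2ccccc2)C1` gives 1820 nM, a lower number with the difference beyond the scatter. Compound 2 `O=C(OCC1CCN(CCCc2ccccc2)CC1)c1ccccc1-c1ccccc1` is entered twice, each time at 10500 nM; 10500 nM (2 entries). Compound 4 `CC1CC(=O)N(c2ccccc2C(=O)OCC2CCCN(CCCC3CCCCC3)C2)C1=O` is not yet measured; it differs from compound 3 by cyclohexyl in place of phenethyl on a saturated chain carbon, three bonds along the chain from an amine nitrogen in a ring. Among the measured compounds shown here, no measured pair in the set makes this change, so its size is open; nothing in the numbers argues for a gain, and a small loss or no move beyond the scatter is the more likely outcome. The expected step from compound 3 to compound 4 is a 1.4-fold higher number from compound 3 to compound 4 (0.16 log units; within the scatter). Compound 4 is estimated at 6000 nM, with a range from 2000 nM to 18000 nM.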

Compound 4, half-maximal inhibitory concentration: 10700 nM
For compound 4 the middle estimate is 1.8-fold (0.25 log units) below the measured one; the measured number falls inside the stated range.
By their numbers in this assay, from the lowest: compound 1; then compound 3; then compound 4.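

In this assay the 5-phenylpentyl to 3-cyclohexylpropyl change gives a 2.6-fold higher number from compound 3 to compound 4 (0.41 log units; beyond the scatter) and so gives this series its first single-place step, showing that this saturated chain position is sensitive to the group it carries. The step combines a non-aromatic ring with a shorter group, so it cannot assign the loss to either. No supporting measurement explains the shift. A 5-cyclohexylpentyl group on the same core would separate ring from chain length. As far as these compounds go, whether a 3-phenylpropyl group on that core retains the activity of compound 3 also remains open.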